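Series notes: methoxy for methyl on the sulfamoyl analogue

The compounds below may be only part of what the source reports. "The series", "measured", "known", "first", "only" and "open" are said of these compounds alone.

Measured so far in a functional assay on the whole organism (strain Wistar albino) for inhibition, with Rattus norvegicus as the target, read by paw edema, with stated times of 1 h and 3 h, at a dose of 0.32 mmol/kg by the intraperitoneal route; on this read-out higher numbers stand for more inhibition at the one dose given (going by the name of the read-out) and lower numbers for less inhibition:
compound 1 `Cc1ccc(-c2nn(-c3ccc(Cl)cc3)cc2C(CC(=O)c2ccc(Cl)cc2)C(=O)c2ccc(F)cc2)cc1`: 19.4%
compound 2 `COc1ccc(-c2nn(-c3ccc(Cl)cc3)cc2C(CC(=O)c2ccc(Cl)cc2)C(=O)c2ccc(F)cc2)cc1`: 37.8%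
compound 3 `Cc1ccc(-c2nn(-c3ccc(S(N)(=O)=O)cc3)cc2C(CC(=O)c2ccc(Cl)cc2)C(=O)c2ccc(F)cc2)cc1`: 56.2%

Compound 3 stands highest of the three numbers shown; compound 2 is nearest, and compound 1 furthest, both steps to it being beyond the scatter. The step from compound 1 to compound 3 is the large one (a number 36.8 percentage points higher from compound 1 to compound 3 (beyond the scatter)), and it is the sulfamoyl that compound 3 carries forward into compound 4.

Compound 4 `COc1ccc(-c2nn(-c3ccc(S(N)(=O)=O)cc3)cc2C(CC(=O)c2ccc(Cl)cc2)C(=O)c2ccc(F)cc2)cc1` differs from compound 3 in one place:
methoxy in place of methyl on an aromatic carbon

Going by the values given here, the only measured step of this kind is the one on the chloro series, a number 18.4 percentage points higher from compound 1 to compound 2 (beyond the scatter), which was modest and beyond the scatter. Nothing shows whether the same change behaves alike on the sulfamoyl compound; the expectation therefore rests on that single step alone. An upward step of about the same size is expected, a number 15.8 percentage points higher from compound 3 to compound 4 (beyond the scatter), though its size is uncertain and could fall short of it.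

Compound 4 is estimated at 72% in this assay, within a range of 58% to 85%.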

Compound 4, a percentage reported as inhibition, in the whole organism at one dose (the size of the read-out at that dose, not a potency): 68.1%
Beside the measured number, compound 4's estimate is 3.9 percentage points above it; the measured number falls inside the stated range.
By their numbers in this assay, from the lowest: compound 1; then compound 2; then compound 3; then compound 4.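

The change from 4-methylphenyl to 4-methoxyphenyl now has a second reading in this assay, on the sulfamoyl compounds, and it again raises the number: a number 11.9 percentage points higher from compound 3 to compound 4 (beyond the scatter). Set against the chloro pair, the two steps agree: the same change on two cores in this assay, a number 18.4 percentage points higher (beyond the scatter) from compound 1 to compound 2 and a number 11.9 percentage points higher (beyond the scatter) from compound 3 to compound 4, 6.5 percentage points apart, within the scatter of two such steps. The sulfamoyl-for-chloro change also carries over to the methoxy compounds, a number 30.3 percentage points higher from compound 2 to compound 4 (beyond the scatter), so across these four compounds the two changes add with no sign that one depends on the other: the same change on two cores in this assay, a number 36.8 percentage points higher (beyond the scatter) from compound 1 to compound 3 and a number 30.3 percentage points higher (beyond the scatter) from compound 2 to compound 4, 6.5 percentage points apart, within the scatter of two such steps.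

From the compounds shown here alone, whether an ethoxy, a hydroxyl or a dimethylamino group in the same place would carry the number further stays open. The compounds shown also leave open whether this order of compounds would hold at other doses.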